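Compound 4: the ethyl ester compared with compound 3

The compounds below may be only part of what the source reports. "The series", "measured", "known", "first", "only" and "open" are said of these compounds alone.

Of the compounds shown here, three sharing one core have been measured in an ADME assay for metabolic stability, read by LC-MS, with a stated time of 3 h, at pH 6.5, tested at 50 uM; a higher number here means that more of the compound is left, a lower number that less of the compound is left. Compound 1 `C[C@@H](O)[C@H]1C(=O)N2C(C(=O)OCOC(=O)C(C)(C)C)=C(S[C@@H]3CN[C@H](C(=O)Nc4cccc(C(=O)O)c4)C3)[C@H](C)[C@H]12` gives > 95%, which is a limit of the assay and not a number. Compound 2 `C[C@@H](O)[C@H]1C(=O)N2C3=C(S[C@@H]4CN[C@@H](C4)C(=O)Nc4cccc(c4)C(=O)OCOCOC3=O)[C@H](C)[C@H]12` likewise gives > 95%, again a limit. Compound 3 `C[C@@H](O)[C@H]1C(=O)N2C(C(=O)OCOC(=O)C3CCCCC3)=C(S[C@@H]3CN[C@H](C(=O)Nc4cccc(C(=O)O)c4)C3)[C@H](C)[C@H]12` gives > 95%, also a limit. Compound 3 therefore stands at the limit together with the two other values shown, as summed up by the limit of > 95% in this assay, at which 3 of the 3 values shown sit; no value in this set is a number. Among the compounds with values here, the one measured step that touches the same part of the molecule, a step that the two limits leave unreadable from compound 1 to compound 3, is unreadable in size, both of its ends being limits.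

Compound 4 `CCOC(=O)C1=C(S[C@@H]2CN[C@H](C(=O)Nc3cccc(C(=O)O)c3)C2)[C@H](C)[C@@H]2[C@@H]([C@@H](C)O)C(=O)N12` differs from compound 3 as follows: methyl in place of (cyclohexylcarbonyl)oxy on a saturated chain carbon bound to an oxygen next to a carbonyl group. With no readable step to lean on, the expectation rests on all three values sitting at the limit (the limit of > 95% in this assay, at which 3 of the 3 values shown sit). Compound 4 is therefore expected to stay at the limit, with the step of a number no higher from compound 3 to compound 4 (the limit leaves the size open) expected to lie within the scatter. The estimate for compound 4 in this assay is 95%, ranging from 85% to 99%.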

Compound 4, percent of the compound remaining: > 95%
Compound 4 ended at the assay's limit (the forecaster's own chance of this, stated with the estimate: 75%); the middle value lies on the limit itself.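

No step can be read from compound 3 to compound 4 or from compound 1 to compound 4 in this assay, as all these values are limits and not numbers: the limit of > 95% in this assay, at which 4 of the 4 values shown sit.

The compounds shown leave open whether the percent of compound remaining differs among them at all.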